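Pyridin-4-yl in Place of Trifluoromethylphenyl: Solubility Outlook

The source may hold more compounds than are shown below. What is called first, only, known or untested is meant among the compounds shown, and "the series" means these compounds.

For the measured compounds named here, compound 3 `CN1CCC(C(=O)N2Cc3c(NC(=O)c4ccc(C(F)(F)F)cc4)n[nH]c3C2(C)C)CC1` gives 191000 nM in a physicochemical assay for solubility, at pH 7 (a higher number here means a more soluble compound, a lower number a less soluble compound), the only number among the three values shown. Compound 1 `CN1CCC(C(=O)N2Cc3c(NC(=O)c4cccc(F)c4)n[nH]c3C2(C)C)CC1` sits at a limit of the assay, > 225000 nM. Compound 2 `CN1CCC(C(=O)N2Cc3c(NC(=O)c4ccc(F)c(F)c4)n[nH]c3C2(C)C)CC1` likewise sits at a limit, > 225000 nM. The step of an at least 1.1-fold lower number from compound 1 to compound 3 (0.07 log units; that floor lies within the scatter) and the step of an at least 1.1-fold lower number from compound 2 to compound 3 (0.07 log units; that floor lies within the scatter) both end at compound 3 and both start from the limit (the limit of > 225000 nM in this assay, at which 2 of the 3 values shown sit). Compound 4 `CN1CCC(C(=O)N2Cc3c(NC(=O)c4ccncc4)n[nH]c3C2(C)C)CC1` differs from compound 3 by pyridin-4-yl in place of 4-(trifluoromethyl)phenyl on a carbonyl carbon. Since the 4-(trifluoromethyl)phenyl group leaves, the change runs in the opposite direction to those two steps, so the expected step is a 1.3-fold higher number from compound 3 to compound 4 (0.12 log units; within the scatter), toward the limit. Compound 4 is therefore estimated at 250000 nM, with a range from 150000 nM to 400000 nM, and a limit rather than a number would not be surprising.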

Compound 4, solubility: > 225000 nM
Compound 4 ended at the assay's limit; the forecaster's own chance of this, stated with the estimate: 60%; the middle value lies beyond the limit too.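

With pyridin-4-yl on the carbonyl carbon, an aromatic ring with a hetero atom now stands at this position, and compound 4 gives a limit, not a number, in this assay: the limit of > 225000 nM in this assay, at which 3 of the 4 values shown sit. Against the one number in the series, the change gives an at least 1.1-fold higher number from compound 3 to compound 4 (0.07 log units; that floor lies within the scatter). The steps to compound 4 from compound 1 and from compound 2 join two limits and cannot be read.

From the compounds shown here alone, how compound 1, compound 2 and compound 4 rank beyond the limit stays open. So does whether an amine, a carboxylic acid or a longer chain on this carbonyl carbon would bring the read-out back to a number.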